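Toward Compound 4: Another Halogen Swap on a Shared Core

The source may report more compounds than this note shows. Statements on the series, on what has been measured and on what is new or still open speak of the compounds shown alone.

Of the compounds shown here, three with one shared core have been measured in an ADME assay on THP-1 cells (Homo sapiens) for cytotoxicity, read by MTT assay, tested at 50 ug/mL; a lower number here means less inhibition, a higher number more inhibition at the concentration tested (going by the name of the read-out). Compound 1 `C(=N/Nc1nc(-c2ccccc2)cs1)\c1ccc(-n2cncn2)cc1` gives 28.4%. Compound 2 `Fc1ccc(-c2csc(N/N=C/c3ccc(-n4cncn4)cc3)n2)cc1` gives 35.9%, and compound 3 `Brc1ccc(-c2csc(N/N=C/c3ccc(-n4cncn4)cc3)n2)cc1` gives 32.6%. The steps between them are small: a number 7.5 percentage points higher from compound 1 to compound 2 (within the scatter), a number 4.2 percentage points higher from compound 1 to compound 3 (within the scatter), and a number 3.3 percentage points lower from compound 2 to compound 3 (within the scatter). Compound 3 therefore sits within the usual scatter of both compound 1 and compound 2, so the three numbers cannot be told apart with confidence.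

Compound 4 `Clc1ccc(-c2csc(N/N=C/c3ccc(-n4cncn4)cc3)n2)c(Cl)c1` is the next member. Compared with compound 3, the change is 2,4-dichlorophenyl in place of 4-bromophenyl on an aromatic carbon. Every step measured so far in this series exchanges one substituent on that same ring for another, and none of those steps reached beyond the scatter. The change to compound 4 is of the same kind, so no step beyond the scatter is expected: a number 1.4 percentage points higher from compound 3 to compound 4 (within the scatter). Compound 4 is thus estimated to give 34% in this assay, with a range from 22% to 46%.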

Compound 4, a percentage reported as inhibition, at one concentration (the size of the read-out at that concentration, not a potency): 8.9%
Compound 4: the middle estimate sits 25.1 percentage points above what was measured, outside the stated range (below it).
By their numbers in this assay, from the lowest: compound 4; then compounds 1, 3 and 2 (each within the scatter of the next).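

In this assay, going by these compounds alone, the group at this position can matter after all: 2,4-dichlorophenyl gives the first steps beyond the scatter, with a number 23.7 percentage points lower from compound 3 to compound 4 (beyond the scatter), a number 27 percentage points lower from compound 2 to compound 4 (beyond the scatter) and a number 19.5 percentage points lower from compound 1 to compound 4 (beyond the scatter). Phenyl, 4-fluorophenyl and 4-bromophenyl could not be told apart, so the new result shows that less inhibition at the tested concentration can be reached by changing this ring, although a swap of one halogen for another showed no such shift. The data shown offer no measured explanation for this drop.

On these data alone, it remains open whether the drop needs both chlorines or would follow from one alone, since compound 4 differs from the others in both the halogen and the number of ring substituents. As far as these compounds go, it is also open whether a methoxy group or an amine on this ring would lower the number in the same way.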